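The source may report more compounds than this note shows. Statements on the series, on what has been measured and on what is new or still open speak of the compounds shown alone.

Measured compounds:
- compound 1, `COc1ccc(/C=C\C(=O)O)c(OCc2cn(-c3ccccc3)nn2)c1CC=C(C)C`: 32300 nM
- compound 2, `COc1ccc(/C=C\C(=O)O)c(OCc2cn(-c3cccc([N+](=O)[O-])c3)nn2)c1CC=C(C)C`: 6900 nM
- compound 3, `COc1cccc(-n2cc(COc3c(/C=C\C(=O)O)ccc(OC)c3CC=C(C)C)nn2)c1`: "not determined" (no result reported)

In a functional assay on COLO 205 cells (Homo sapiens) for cytotoxicity, read by MTT assay, with a stated time of 24 h (on this read-out lower numbers stand for stronger inhibition and higher numbers for weaker inhibition), compound 1 gives 32300 nM and compound 2 gives 6900 nM. Compound 2 therefore has the lowest of the two numbers in this assay; compound 3 stands without a number. Among the measured compounds shown here, the one measured step is a 4.7-fold lower number from compound 1 to compound 2 (0.67 log units; beyond the scatter).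

Compound 4, `COc1ccc(/C=C\C(=O)O)c(OCc2cn(-c3nc4ccccc4s3)nn2)c1CC=C(C)C`, is not yet measured. It differs from compound 2 in one place: 1,3-benzothiazol-2-yl in place of 3-nitrophenyl on an aromatic nitrogen. For the measured compounds named here, no measured step shows this exact exchange. Going by the values given here, the only step that bears on it is the one from compound 1 to compound 2, where the nitro group that now leaves was gained, and it gave a 4.7-fold lower number from compound 1 to compound 2 (0.67 log units; beyond the scatter). With that group gone and a new ring system entering, the number for compound 4 is expected to move back toward that of compound 1, by a modest amount, though a group this different could also fall elsewhere. The step from compound 2 to compound 4 is estimated as a 2.2-fold higher number from compound 2 to compound 4 (0.34 log units; beyond the scatter). Compound 4 is expected to give about 15000 nM in this assay, within a range from 5000 nM to 45000 nM.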

Compound 4, half-maximal inhibitory concentration: 20200 nM
Estimate against measurement, compound 4: 1.3-fold (0.13 log units) below; the range from low to high includes it.
By their numbers in this assay, from the lowest: compound 2; then compounds 4 and 1 (each within the scatter of the next).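

In this assay, 1,3-benzothiazol-2-yl in place of 3-nitrophenyl on the aromatic nitrogen gives a 2.9-fold higher number from compound 2 to compound 4 (0.47 log units; beyond the scatter), even though the leaving and entering groups match in their counts of heavy atoms and hydrogen-bond acceptors, so those matching counts do not bring matching numbers for this pair. Set against the plain phenyl group, the same two-ring group gives a 1.6-fold lower number from compound 1 to compound 4 (0.20 log units; within the scatter), so compound 4 does not keep the advantage that compound 2 holds over compound 1. Nothing available explains why this exchange moves the number as it does.

Still open, as far as these compounds go, is whether the lower number of compound 2 belongs to the nitro group itself, or whether an amine or a chlorine atom on the phenyl ring would serve as well. Also open, from the compounds shown here alone, is how an amine on the 1,3-benzothiazol-2-yl group would change the number of compound 4.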